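The source may report more compounds than this note shows. Statements on the series, on what has been measured and on what is new or still open speak of the compounds shown alone.

Measured so far: compound 1 `O=C(O)Cn1nc(Cc2nc3cc(Cl)c(OCC(F)F)cc3[nH]2)c2ccccc2c1=O`, 12 nM; compound 2 `CC(C(=O)O)c1nn(Cc2cn3cc(OCC4CC4)c(Cl)cc3n2)c2ccccc2c1=O`, 6 nM; compound 3 `CCOc1cc2[nH]c(Cc3nn(CC(=O)O)c(=O)c4ccccc34)nc2cc1Cl`, 17 nM, all in a functional assay on CHO cells for antagonist activity at sphingosine 1-phosphate receptor 2 (Homo sapiens), read by calcium flux; a higher number here means a weaker inhibitor, a lower number a stronger inhibitor.

Compound 2 gives the lowest of the three numbers; compound 1 sits within the scatter of it, while compound 3 lies beyond it. Compound 4 `CCC(C(=O)O)c1nn(Cc2cn3cc(OCC4CC4)c(Cl)cc3n2)c2ccccc2c1=O` differs from compound 2 by methyl in place of hydrogen on a saturated chain carbon, two bonds along the chain from an aromatic carbon and a carbonyl carbon. Within the data shown here, no measured step touches this position: the one step on record, a 1.4-fold higher number from compound 1 to compound 3 (0.15 log units; within the scatter), sits on a saturated chain carbon bound to an oxygen on an aromatic ring and stayed within the scatter. Among the measured compounds shown here, compounds 1 and 3 differ from compound 2 in more than one place, so their values show only that compound 2 gives the lowest number. No step beyond the scatter is therefore expected, a 1.2-fold higher number from compound 2 to compound 4 (0.07 log units; within the scatter). Compound 4 is estimated at 7 nM in this assay, with a range from 3 nM to 18 nM.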

Compound 4, half-maximal inhibitory concentration: 5.6 nM
The estimate for compound 4 lay 1.3-fold (0.10 log units) above the measured number; low and high end bracket the measured number.
By their numbers in this assay, from the lowest: compounds 4, 2, 1 and 3 (each within the scatter of the next, the first and the last beyond it).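

In this assay, methyl in place of hydrogen on this saturated chain carbon, which turns 1-carboxyethyl into 1-carboxypropyl, gives a 1.1-fold lower number from compound 2 to compound 4 (0.03 log units; within the scatter) and so stays within the scatter. Among these compounds, this is the first step on record at this position, and it shows that the number holds when this one methyl is added there. Nothing available gives a reason for this result.

The compounds shown leave open whether a longer chain, a cyclopropyl ring or an amine on this same carbon would also hold the number. They also leave open whether the carboxylic acid itself can be replaced, for example by a tetrazole.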